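This account rests on a few compounds, and the source may have more. Where it says the series, first, only, none or still open, it means among the compounds named here.

Of the compounds shown here, two have so far been measured in an ADME assay on microsomes from liver (Homo sapiens) for metabolic stability, read by LC-MS, using NADPH, tested at 5 uM; on this read-out higher numbers stand for a longer-lived compound and lower numbers for a shorter-lived compound. Compound 1, with the structure `NS(=O)(=O)c1cc(-c2nnc(CN3CCN(c4ccc(Cl)cc4)CC3)o2)c(Cl)cc1SCc1ccccc1`, gives 0.455 h in this assay. Compound 2, with the structure `CC(C)(O)c1cn(Cc2nnc(-c3cc(S(N)(=O)=O)c(SCc4ccccc4)cc3Cl)o2)nn1`, gives 0.23 h in this assay. Compound 2 has the lower of the two numbers, but its nearest neighbour, compound 1, lies within the scatter of repeated measurements, so the two values are not told apart with confidence. Going by the values given here, no pair of measured compounds differs in a single place, so no single-point step has yet been observed.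

The compound now in question is compound 3, with the structure `NS(=O)(=O)c1cc(-c2nnc(/C=C/c3c(Cl)cccc3Cl)o2)c(Cl)cc1SCc1ccccc1`. The change from compound 2 to compound 3 is 2-(2,6-dichlorophenyl)ethenyl in place of (4-(1-hydroxy-1-methylethyl)-1H-1,2,3-triazol-1-yl)methyl on an aromatic carbon. The group that enters carries no hydrogen-bond donor or acceptor, whereas the group that leaves carries one donor and four acceptors.

Among the compounds with values here, with no measured step of this kind to lean on, the step from compound 2 to compound 3 is expected to be small, a 1.3-fold higher number from compound 2 to compound 3 (0.12 log units; within the scatter), not clearly beyond the scatter in either direction. Compound 3 is therefore estimated at 0.3 h in this assay, within a range from 0.12 h to 0.8 h.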

Compound 3, half-life: 0.468 h
Estimate against measurement, compound 3: 1.6-fold (0.19 log units) below; the measured number falls inside the stated range.
By their numbers in this assay, from the lowest: compounds 2, 1 and 3 (each within the scatter of the next, the first and the last beyond it).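

In this assay, going by these compounds alone, placing 2-(2,6-dichlorophenyl)ethenyl in place of (4-(1-hydroxy-1-methylethyl)-1H-1,2,3-triazol-1-yl)methyl on an aromatic carbon of the five-membered aromatic ring with 2 nitrogen and 1 oxygen gives a 2.0-fold higher number from compound 2 to compound 3 (0.31 log units; beyond the scatter) and is the first single-place step seen at this position. Both groups hold 10 heavy atoms, but the one that leaves carries 1 hydrogen-bond donor and 4 hydrogen-bond acceptors, while the one that enters carries neither and brings 2 chlorine, so a marked change in make-up at this position is here accompanied by a longer half-life rather than a shorter one. Nothing measured ties the step to any single feature of either group, whether the triazole, the hydroxyl, the double bond or the chlorines.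

Still open, on these data alone, is how a plain phenyl without chlorine, or a saturated two-carbon chain in place of the double bond, would read at this position. Also open, as far as these compounds go, is whether an amine or a carboxylic acid on the same carbon would follow the same direction.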